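Chromone acrylamides: amide-nitrogen substituent series, next benzyl variant

A few compounds are considered here, and "the series" means these few. Any claim that something is new, unique, unknown or untested is made for them only; others in the source may bear on it.

Measured so far:
compound 1 `COc1ccc2c(=O)c(/C=C/C(=O)Nc3ccccc3Cl)coc2c1` — 23000 nM
compound 2 `COc1ccc2c(=O)c(/C=C/C(=O)NCc3ccccc3F)coc2c1` — 34000 nM

In a functional assay (QGY7701 cells, Homo sapiens) for inhibition, read by MTT assay, with a stated time of 48 h (a higher number here means a weaker inhibitor, a lower number a stronger inhibitor), compound 1 gives 23000 nM and compound 2 gives 34000 nM. Within the data shown here, the only step between them, a 1.5-fold higher number from compound 1 to compound 2 (0.17 log units; within the scatter), lies within the scatter, so the two numbers are not ordered; compound 2 simply carries the higher of the two readings, with compound 1 nearest.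

Compound 3 `COc1ccc(CNC(=O)/C=C/c2coc3cc(OC)ccc3c2=O)cc1` is not yet measured in this assay. Its change from compound 2 is 4-methoxyphenyl in place of 2-fluorophenyl on a saturated chain carbon bound to an amide-type nitrogen. Among the measured compounds shown here, no measured step touches this change: the one step known, a 1.5-fold higher number from compound 1 to compound 2 (0.17 log units; within the scatter), swaps the whole nitrogen substituent and stays within the scatter, and no pair compares two benzyl groups. For the measured compounds named here, the only evidence is that a change on the amide-type nitrogen did not move this assay beyond the scatter; on that basis a step of a 1.1-fold lower number from compound 2 to compound 3 (0.05 log units; within the scatter) is expected, that is, none beyond the scatter. Compound 3 is therefore estimated at 30000 nM, within 12000 nM to 80000 nM.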

Compound 3, half-maximal inhibitory concentration: 15700 nM
For compound 3 the middle estimate is 1.9-fold (0.28 log units) above the measured one; the measured number falls inside the stated range.
By their numbers in this assay, from the lowest: compounds 3, 1 and 2 (each within the scatter of the next, the first and the last beyond it).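

In this assay, among these compounds, the benzyl group on the amide-type nitrogen gives the first single change to pass the scatter: 4-methoxyphenyl in place of 2-fluorophenyl on a saturated chain carbon gives a 2.2-fold lower number from compound 2 to compound 3 (0.34 log units; beyond the scatter) and counts as a modest step. Among the compounds shown here, exchanging the whole nitrogen substituent, 4-methoxybenzyl in place of 2-chlorophenyl, gives a 1.5-fold lower number from compound 1 to compound 3 (0.17 log units; within the scatter) and leaves that pair unordered, so the only step beyond the scatter so far lies between the two benzyl groups. No measurement on hand accounts for that step.

From the compounds shown here alone, the two benzyl groups differ in both substituent and its place on the ring, so it remains open which of the two carries the step. An unsubstituted benzyl group would serve as a common reference for both, and a phenethyl chain would show whether the shift survives a longer link to the nitrogen.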